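Neopentyl for phenyl, from one core to another

This account rests on a few compounds, and the source may have more. Where it says the series, first, only, none or still open, it means among the compounds named here.

Compound 1 `O=C([C@H](O)c1ccccc1)N1CC[C@@H]2C[C@@]21C(=O)NCc1cc(Cl)ccc1-n1cnnn1` gives 43 mL.min-1.g-1 in an ADME assay on liver for metabolic stability, with Liver microsome (Homo sapiens) as the target, read by LC-MS, using microsomes; a higher number here means faster removal of the compound, a lower number slower removal.
Compound 2 `CC(C)(C)C[C@@H](O)C(=O)N1CC[C@@H]2C[C@@]21C(=O)NCc1cc(Cl)ccc1-n1cnnn1` gives 27 mL.min-1.g-1 in this assay.
Compound 3 `O=C(NCc1cc(Cl)ccc1-n1cnnn1)[C@@H]1CCON1C(=O)[C@H](O)c1ccccc1` gives < 12 mL.min-1.g-1 in this assay.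

Compound 1 and compound 2 share a core and differ in one place: neopentyl in place of phenyl on a saturated chain carbon bound to a carbonyl carbon and an oxygen on a saturated carbon. In this assay this change gave a 1.6-fold lower number from compound 1 to compound 2 (0.20 log units; within the scatter). For compound 3 the value is a limit of this assay and not a number, as the limit of < 12 mL.min-1.g-1 in this assay, at which 1 of the 3 values shown sits, records. How the core of compound 3 differs from that of compound 1 is not broken down here.

Compound 4 `CC(C)(C)C[C@@H](O)C(=O)N1OCC[C@H]1C(=O)NCc1cc(Cl)ccc1-n1cnnn1` has not yet been measured. It relates to compound 3 as compound 2 does to compound 1: neopentyl in place of phenyl on a saturated chain carbon bound to a carbonyl carbon and an oxygen on a saturated carbon. The two places read the same word for word, so this is the same change made on a second core.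

The expected step is a step that the limit leaves unreadable from compound 3 to compound 4, resting on a 1.6-fold lower number from compound 1 to compound 2 (0.20 log units; within the scatter) seen between compound 1 and compound 2, which lay within the scatter. Since compound 3 already sits at the limit recorded in the limit of < 12 mL.min-1.g-1 in this assay, at which 1 of the 3 values shown sits, the estimate for compound 4 in this assay is 8 mL.min-1.g-1, with a range from 3 mL.min-1.g-1 to 15 mL.min-1.g-1, and a further limit reading is likely.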

Compound 4, intrinsic clearance in microsomes: < 12 mL.min-1.g-1
Compound 4 was reported as a limit (the forecaster's own chance of this, stated with the estimate: 70%); the middle value does not contradict the limit.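

In this assay compound 4 gives < 12 mL.min-1.g-1, which is a limit and not a number. Compound 3 is also recorded only as a limit, so no step between compound 3 and compound 4 can be read: the limit of < 12 mL.min-1.g-1 in this assay, at which 2 of the 4 values shown sit.

As far as these compounds go, whether neopentyl in place of phenyl changes the clearance on this second core, and by how much, remains open.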